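This account rests on a few compounds, and the source may have more. Where it says the series, first, only, none or still open, it means among the compounds named here.

Working notes on the series. Compound 1 `COc1cccc(CNCCCNc2ccnc3cc(Oc4ccc(Cl)cc4)ccc23)c1O` gives 5700 nM in an ADME assay on HepG2 cells (Homo sapiens) for cytotoxicity, read by luminescence, CellTiter-Glo and ATP content, with a stated time of 72 h; a higher number here means that more compound is needed for the effect, a lower number that less compound is needed. Compound 2 `COc1cccc(CNCCCNc2ccnc3cc(Oc4ccccc4)ccc23)c1O` gives 6800 nM in this assay, and compound 3 `COc1cccc(CNCCCNc2ccnc3cc(Oc4cccc(N(C)C)c4)ccc23)c1O` gives 7300 nM in this assay. Compound 3 carries the highest of the three numbers, but its separations from the other two, a 1.1-fold higher number from compound 2 to compound 3 (0.03 log units; within the scatter) and a 1.3-fold higher number from compound 1 to compound 3 (0.11 log units; within the scatter), are within the scatter, so the three measured compounds read as a single level in this assay.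

Compound 4 `COc1cccc(CNCCCNc2ccnc3cc(Cc4cccc(C(F)(F)F)c4)ccc23)c1O` is not yet measured. Its change from compound 3 is 3-(trifluoromethyl)benzyl in place of 3-(dimethylamino)phenoxy on an aromatic carbon. All three measured steps touch this same part of the core: a 1.2-fold higher number from compound 1 to compound 2 (0.08 log units; within the scatter), a 1.3-fold higher number from compound 1 to compound 3 (0.11 log units; within the scatter) and a 1.1-fold higher number from compound 2 to compound 3 (0.03 log units; within the scatter), each within the scatter. So far the phenoxy group has tolerated a chloro, a hydrogen and a dimethylamino without any effect beyond the scatter. Within the data shown here, none of the measured steps, however, exchanges a phenoxy for a benzyl, and none introduces a trifluoromethyl, so the change in compound 4 is of a kind not yet covered. On the evidence available, the expected step is none beyond the scatter, with wider uncertainty than for a step already measured.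

For compound 4 the expected value in this assay is 7000 nM, with a range from 3000 nM to 16000 nM. This estimate for compound 4 corresponds to an expected step of a 1.0-fold lower number from compound 3 to compound 4 (0.02 log units; within the scatter).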

Compound 4, half-maximal effective concentration: 1720 nM
Compound 4: middle estimate off by 4.1-fold (0.61 log units), on the high side; the measured number lies below the stated range.
By their numbers in this assay, from the lowest: compound 4; then compounds 1, 2 and 3 (each within the scatter of the next).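

In this assay, among these compounds, exchanging the aryloxy group on the aromatic carbon for 3-(trifluoromethyl)benzyl is the first change at this position to go beyond the scatter, with a 4.2-fold lower number from compound 3 to compound 4 (0.63 log units; beyond the scatter), a 4.0-fold lower number from compound 2 to compound 4 (0.60 log units; beyond the scatter) and a 3.3-fold lower number from compound 1 to compound 4 (0.52 log units; beyond the scatter). The number at this position therefore does respond to a change, although exchanging chloro, hydrogen and dimethylamino on the phenoxy ring gave steps that stayed within the scatter. All three new steps point the same way and are of similar size whichever phenoxy group leaves, but nothing available explains the drop in the number.

The change in compound 4 replaces the oxygen link with a carbon link and brings in the trifluoromethyl group at once, so the step cannot yet be assigned to either part; a phenoxy ring carrying trifluoromethyl and a plain benzyl group would separate the two. On these data alone, how far the lower number extends to other links at this position, such as an amine or a carbonyl, also remains open.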